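The source may hold more compounds than are shown below. What is called first, only, known or untested is meant among the compounds shown, and "the series" means these compounds.

Working notes on the series. In a functional assay on MDA-MB-435 cells (Homo sapiens) for cytotoxicity, read by MTT assay, with a stated time of 72 h (on this read-out lower numbers stand for stronger inhibition and higher numbers for weaker inhibition), compound 2 (`N[C@H]1CC[C@H](Nc2c(C(=O)NCc3ccc(Cl)cc3Cl)nc(Br)c3cccnc23)CC1`) gives 5800 nM and compound 1 (`Nc1ccc(Nc2c(C(=O)NCc3ccc(F)cc3)nc(Br)c3cccnc23)cc1`) gives 7000 nM, two values within the scatter of each other. Compound 3 (`O=C(NCCCNc1c(C(=O)NCc2ccc(F)cc2)nc(Br)c2cccnc12)c1ccccc1`) reaches only a limit of the assay, > 20000 nM. Compound 4 (`N[C@H]1CC[C@H](Nc2c(C(=O)NC3CCCCC3)nc(Br)c3cccnc23)CC1`) carries cyclohexyl in place of 2,4-dichlorobenzyl on an amide-type nitrogen. Going by the values given here, no measured compound has cyclohexyl at that place, so the expectation is a loose one. A modest weakening in this assay is expected, toward higher numbers and only slightly beyond the scatter. The expected size is a step of a 1.7-fold higher number from compound 2 to compound 4 (0.24 log units; within the scatter). For compound 4 the estimated value is 10000 nM, with an expected range of 3500 nM to 25000 nM.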

Compound 4, half-maximal inhibitory concentration: > 10000 nM
Compound 4: only a limit was reported; the forecaster's own chance of this, stated with the estimate: 30%; the middle value sits exactly at the limit.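

Compound 4 alone among the compounds shown carries cyclohexyl on the amide-type nitrogen, and its value is a limit: the limit of > 10000 nM in this assay, at which 1 of the 4 values shown sits. In this assay the change reads as an at least 1.7-fold higher number from compound 2 to compound 4 (0.23 log units; that floor lies within the scatter). Cyclohexyl therefore shows no gain over 2,4-dichlorobenzyl at this place, while the real size of the step stays unread.

The compounds shown leave open whether the aromatic ring or the two chlorine atoms count here. A plain benzyl group at this nitrogen, with the rest of compound 2 unchanged, would separate the two.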